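The source may hold more compounds than are shown below. What is called first, only, known or untested is meant among the compounds shown, and "the series" means these compounds.

Compound 1 `C=CC1=C(C(=O)O)C(c2ccc(OC)cc2)OC1`: 44300 nM. Compound 2 `C=CC1=C(C(=O)Nc2ccccc2)C(c2ccc(OC)cc2)OC1`: > 100000 nM, a limit of the assay.

In a functional assay on HeLa cells (Homo sapiens) for cytotoxicity, read by MTT assay, with a stated time of 24 h (a higher number here means a weaker inhibitor, a lower number a stronger inhibitor), compound 1 gives 44300 nM. For compound 2 the value > 100000 nM is a limit of the assay, not a number, so compound 2 sits at the limit of > 100000 nM in this assay, at which 1 of the 2 values shown sits. Among the compounds with values here, the only measured step is an at least 2.2-fold higher number from compound 1 to compound 2 (0.35 log units; beyond the scatter), a weakening. Compound 3 `C=CC1=C(C(=O)NC2CCCCC2)C(c2ccc(OC)cc2)OC1` differs from compound 2 by cyclohexyl in place of phenyl on an amide-type nitrogen. Within the data shown here, no measured step covers this change, so no shift beyond the scatter is expected in either direction, and compound 3 is expected to remain near the limit. The estimate for compound 3 is 100000 nM, between 40000 nM and 300000 nM, an expected step of a number no higher from compound 2 to compound 3 (the limit leaves the size open).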

Compound 3, half-maximal inhibitory concentration: 24800 nM
For compound 3 the middle estimate is 4.0-fold (0.61 log units) above the measured one; measured number below the stated range.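

In this assay, the ring on the amide-type nitrogen matters: cyclohexyl in place of phenyl, the same carbon count without aromaticity, gives an at least 4.0-fold lower number from compound 2 to compound 3 (0.60 log units; beyond the scatter). The amide itself therefore need not weaken the compound, since cyclohexylamino in place of hydroxy gives a 1.8-fold lower number from compound 1 to compound 3 (0.25 log units; within the scatter). Compound 2 stands at a limit of the assay, not a number, so the full size of the first step stays open: the limit of > 100000 nM in this assay, at which 1 of the 3 values shown sits.

From the compounds shown here alone, whether an open chain such as n-hexyl or a benzyl group on that nitrogen would behave like cyclohexyl or like phenyl remains open.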